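The source may report more compounds than this note shows. Statements on the series, on what has been measured and on what is new or still open speak of the compounds shown alone.

Among the compounds with values here, compound 2 `CCOC(=O)c1ccc(-c2nn(Cc3cccc(F)c3)c3ccccc23)cc1` gives 270 nM in a functional assay on cells (Platelet, Homo sapiens) for inhibition (on this read-out lower numbers stand for stronger inhibition and higher numbers for weaker inhibition), the higher of the two numbers known so far; compound 1 `CCOC(=O)c1ccc(-c2nn(Cc3ccc(Cl)cc3)c3ccccc23)cc1` gives 120 nM in this assay, and the step of a 2.3-fold higher number from compound 1 to compound 2 (0.35 log units; beyond the scatter) is the only measured one. Compound 3 `CCOC(=O)c1ccc(-c2nn(Cc3cccc(OC)c3)c3ccccc23)cc1` differs from compound 2 by methoxy in place of fluoro on an aromatic carbon. Within the data shown here, no measured step exchanges fluoro for methoxy, and the single known step concerns a different change, so it gives no direction. The step from compound 2 to compound 3 is therefore expected to stay within the scatter, no change at the digits printed from compound 2 to compound 3 (within the scatter). Compound 3 is estimated at 270 nM, between 100 nM and 750 nM.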

Compound 3, half-maximal inhibitory concentration: 260 nM
Beside the measured number, compound 3's estimate is 1.0-fold (0.02 log units) above it, within the range that was stated.
By their numbers in this assay, from the lowest: compound 1; then compounds 3 and 2 (each within the scatter of the next).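

Replacing 3-fluorobenzyl with 3-methoxybenzyl leaves the read-out in this assay level, with a 1.0-fold lower number from compound 2 to compound 3 (0.02 log units; within the scatter), so this place on the ring accepts methoxy, with its two heavy atoms and one hydrogen-bond acceptor, on a par with fluoro. Compound 3 also stays apart from the 4-chlorophenyl compound, with a 2.2-fold higher number from compound 1 to compound 3 (0.34 log units; beyond the scatter). Nothing available here explains this equivalence. Still open, from the compounds shown here alone, is whether an amine or a carboxylic acid at this place would hold the number at this level. The compounds shown also do not separate the effect of the chloro group from that of its place on the ring.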